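Pyridin-3-yl for Pyridin-4-yl: Notes Toward Compound 3

This account rests on a few compounds, and the source may have more. Where it says the series, first, only, none or still open, it means among the compounds named here.

Measured so far, in a functional assay on HEK293 cells for negative allosteric modulation of metabotropic glutamate receptor 5 (Homo sapiens), read by calcium flux, with a stated time of 20 min; a lower number here means a stronger inhibitor, a higher number a weaker inhibitor:
compound 1 `CC(C)(C)c1cc2n(n1)CCN(C(=O)c1ccc3ccccc3c1)C2` gives 477 nM
compound 2 `O=C(c1ccccc1)N1CCn2nc(-c3ccncc3)cc2C1` gives 1290 nM

Compound 2 stands at the higher of the two numbers; compound 1 lies lower, and the gap between the two is beyond the scatter. The two differ in more than one place, so nothing can be drawn from them about any single change.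

Compound 3 `O=C(c1ccccc1)N1CCn2nc(-c3cccnc3)cc2C1` differs from compound 2 by pyridin-3-yl in place of pyridin-4-yl on an aromatic carbon. Among the compounds with values here, no measured pair of this series shows a change of this kind, so the size of the step is not known from the data. The expectation is a step from compound 2 to compound 3 of a 1.2-fold higher number from compound 2 to compound 3 (0.07 log units; within the scatter), that is, none clearly beyond the scatter, with the direction open. Compound 3 is thus expected to give about 1500 nM in this assay, with a range from 500 nM to 5000 nM.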

Compound 3, half-maximal inhibitory concentration: > 10000 nM
Compound 3 gave a limit, no number; the forecaster's own chance of this, stated with the estimate: 10%; middle value at least 6.6-fold (0.82 log units) away from the limit.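

Within the data shown here, the pyridin-4-yl to pyridin-3-yl exchange, on the aromatic carbon next to the ring nitrogen, is the only single-place change so far, and it gives an at least 7.7-fold higher number from compound 2 to compound 3 (0.88 log units; beyond the scatter). The two groups have the same counts of atoms, donors and acceptors, so this carbon does not accept the two pyridinyl groups interchangeably, and the placement of the pyridine nitrogen alone separates compound 2 from compound 3 in this assay. Compound 3 gives > 10000 nM, which is a limit of the assay and not a number, so the step has a known minimum but no known size: the limit of > 10000 nM in this assay, at which 1 of the 3 values shown sits.

Open, going by these compounds, is whether a plain phenyl or a pyridin-2-yl at this carbon would read closer to compound 2 or to compound 3. Also open, on these data alone, is whether a methoxy or amino group on the pyridin-3-yl ring would recover any activity.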